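Replacing (3,4-dimethylphenyl)amino with dipropylamino

This account rests on a few compounds, and the source may have more. Where it says the series, first, only, none or still open, it means among the compounds named here.

In a functional assay on MGC-803 cells (Homo sapiens) for inhibition, read by sulforhodamine B assay (on this read-out higher numbers stand for weaker inhibition and lower numbers for stronger inhibition), compound 1 `O=C1C=C(NC2CCCCC2)C(=O)c2c1nc1n2[C@H]2OC[C@@H](O)[C@H]2OC1` reads > 8000 nM, which is a limit of the assay and not a number. For the measured compounds named here, compound 2 `Cc1ccc(NC2=CC(=O)c3nc4n(c3C2=O)[C@H]2OC[C@@H](O)[C@H]2OC4)cc1C` gives 860 nM, the only true number so far. Compound 3 `CCCN(CCC)C1=CC(=O)c2nc3n(c2C1=O)[C@H]1OC[C@@H](O)[C@H]1OC3` carries dipropylamino in place of (3,4-dimethylphenyl)amino on a double-bonded ring carbon. Going by the values given here, the sole measured step bearing on this is an at least 9.3-fold lower number from compound 1 to compound 2 (0.96 log units; beyond the scatter), where cyclohexyl gave way to 3,4-dimethylphenyl on the amine nitrogen. Since compound 3 also lacks that aromatic ring, a move toward weaker inhibition in this assay is expected, with an estimated 3.5-fold higher number from compound 2 to compound 3 (0.54 log units; beyond the scatter). Compound 3 is expected at about 3000 nM, within an estimated range of 900 nM to 10000 nM.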

Compound 3, half-maximal inhibitory concentration: > 16000 nM
Compound 3 was reported as a limit; the forecaster's own chance of this, stated with the estimate: 35%; at least 5.3-fold (0.72 log units) between middle value and limit.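

In this assay, dipropylamino in place of (3,4-dimethylphenyl)amino on this double-bonded ring carbon gives an at least 18-fold higher number from compound 2 to compound 3 (1.26 log units; beyond the scatter). This change removes the aromatic ring and the hydrogen-bond donor together, whereas the cyclohexylamino of compound 1 keeps the donor and lacks only the ring. Compound 1 and compound 3 both read as limits of the assay, so the step between them cannot be read.

On these data alone, it remains open how plain phenylamino, without the two methyl groups, or propylamino would read here. Whether benzylamino, with its ring set one carbon further out, would match compound 2 also stays unanswered.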